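The compounds below may be only part of what the source reports. "The series", "measured", "known", "first", "only" and "open" are said of these compounds alone.

Going by the values given here, in an ADME assay on A549 cells (Homo sapiens) for cytotoxicity, read by CellTiter-Glo (a lower number here means that less compound is tolerated, a higher number that more compound is tolerated), compound 2 `Cc1c(Cc2ccccc2)c(=O)oc2cc(OCC(O)CNc3nccs3)ccc12` gives 93000 nM, the only plain number among the two measured compounds. Compound 1 `Cc1c(Cc2ccccc2)c(=O)oc2cc(OCC(O)CNCC3CC3)ccc12` reaches only a limit in this assay, > 100000 nM, so it is not a number. Among the compounds with values here, the one measured step, an at least 1.0-fold lower number from compound 1 to compound 2 (0.03 log units; that floor lies within the scatter), exchanges a cyclopropylmethyl for a 1,3-thiazol-2-yl on the amine nitrogen and stays within the scatter, and the limit of > 100000 nM in this assay, at which 1 of the 2 values shown sits, shows that this step rests on a value that sits at the limit. Compound 3 `Cc1c(Cc2ccccc2)c(=O)oc2cc(OCC(O)CNn3ccnn3)ccc12` carries a further change at the same amine nitrogen: 1H-1,2,3-triazol-1-yl in place of 1,3-thiazol-2-yl on an amine nitrogen. Because an at least 1.0-fold lower number from compound 1 to compound 2 (0.03 log units; that floor lies within the scatter) shows no shift beyond the scatter when the group on this nitrogen is exchanged, the expected step for compound 3 is a 1.0-fold lower number from compound 2 to compound 3 (0.01 log units; within the scatter), which means no change beyond the scatter. For compound 3 the estimate in this assay is therefore 90000 nM, with a range from 40000 nM to 200000 nM, and a fair chance that the assay again returns only a limit.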

Compound 3, half-maximal cytotoxic concentration: > 100000 nM
Compound 3 was reported as a limit; the forecaster's own chance of this, stated with the estimate: 50%; middle value at least 1.1-fold (0.04 log units) away from the limit.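

In this assay, placing 1H-1,2,3-triazol-1-yl on the amine nitrogen instead of 1,3-thiazol-2-yl gives an at least 1.0-fold higher number from compound 2 to compound 3 (0.03 log units; that floor lies within the scatter) and so stays within the scatter, even though the entering five-membered aromatic ring holds three hetero atoms instead of two and carries no sulfur. Compound 3 is reported only as a limit, not as a number. The step between compound 1 and compound 3 cannot be read, and the step shown here is only a floor, because most of the series rests on a limit rather than on a number: the limit of > 100000 nM in this assay, at which 2 of the 3 values shown sit.

On these data alone, how far compound 3 really lies from compound 2 therefore stays open, since a limit gives no exact value to compare. As far as these compounds go, it is also open whether a different kind of group on this amine nitrogen, such as a carboxylic acid or a longer chain, would bring the reading clearly below the limit and so show that this position can change how much compound the cells tolerate.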